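Fluoro removal from compound 2: expected cytotoxicity

The source may report more compounds than this note shows. Statements on the series, on what has been measured and on what is new or still open speak of the compounds shown alone.

Measured so far:
compound 1 `COc1ccc(/C=C2\CCC/C(=C\c3ccccc3[N+](=O)[O-])C2=O)cc1` — 8900 nM
compound 2 `O=C1/C(=C/c2ccc(F)cc2)CCC/C1=C\c1ccc([N+](=O)[O-])cc1` — 17100 nM
compound 3 `O=C1/C(=C/c2ccc(Cl)cc2)CCC/C1=C\c1ccccc1[N+](=O)[O-]` — 3860 nM

All three share one core and were tested in a functional assay on MOLT-4 cells (Homo sapiens) for cytotoxicity, with a stated time of 72 h; a lower number here means a stronger inhibitor, a higher number a weaker inhibitor. Compound 2 gives the highest of the three numbers; against compound 3 the gap lies beyond the scatter, while the number for compound 1 sits within the scatter of it, so no order between compound 1 and compound 2 can be read.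

Compound 4 `O=C1/C(=C/c2ccccc2)CCC/C1=C\c1ccc([N+](=O)[O-])cc1` is not yet measured. It differs from compound 2 by hydrogen in place of fluoro on an aromatic carbon; cut one bond further out, the change reads 4-fluorophenyl to phenyl.

Among the measured compounds shown here, only one measured step exists: a 2.3-fold lower number from compound 1 to compound 3 (0.36 log units; beyond the scatter). For the measured compounds named here, it swaps one substituent for another on an aromatic carbon and is modest in size; no measured step removes a substituent altogether, and none touches a fluoro. The data therefore give no direct guide, and the closest analogy suggests a change at or near the scatter.

For compound 4 the expectation is a step of a 1.1-fold higher number from compound 2 to compound 4 (0.02 log units; within the scatter) in this assay, that is, no clear change beyond the scatter. Compound 4 is estimated at 18000 nM, with a range from 7000 nM to 45000 nM.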

Compound 4, half-maximal inhibitory concentration: 8350 nM
The estimate for compound 4 lay 2.2-fold (0.33 log units) above the measured number; the measured number falls inside the stated range.
By their numbers in this assay, from the lowest: compound 3; then compounds 4, 1 and 2 (each within the scatter of the next, the first and the last beyond it).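

In this assay the 4-fluorophenyl to phenyl change gives a 2.0-fold lower number from compound 2 to compound 4 (0.31 log units; beyond the scatter), so fluoro on this aromatic carbon, para to a large group, is not interchangeable with hydrogen, and hydrogen carries the lower number. Among the compounds shown here, this is the first measured step that removes a substituent outright, and it shows that this kind of site responds to a removal as well as to the swap seen in a 2.3-fold lower number from compound 1 to compound 3 (0.36 log units; beyond the scatter), a pair that differs from this one elsewhere in the structure. Nothing at hand bears on the cause of the new step.

On these data alone, whether the same removal would give a step of similar size on the core of compound 3, where the nitro group is placed differently, stays open. Also open is how an amine or a carboxylic acid on this aromatic carbon would read against hydrogen and fluoro, and whether the order seen here would hold in cells other than the one line shown.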